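The source may hold more compounds than are shown below. What is called first, only, known or untested is meant among the compounds shown, and "the series" means these compounds.

In a functional assay on MCF7 cells (Homo sapiens) for antiproliferative activity, read by MTT assay, with a stated time of 72 h (a lower number here means a stronger inhibitor, a higher number a weaker inhibitor), compound 1 (`CCn1cc(C(CC)(CC)c2ccc(C#CC(O)(CC)CC)c(C)c2)cc1C(=O)NCCCN(C)C`) gives 20200 nM as a measured number. Compound 2 (`CCCCC(=O)c1cc(C(CC)(CC)c2ccc(C#CC(O)(CC)CC)c(C)c2)cn1CC`) reads > 50000 nM in this assay and that entry is a limit, not a number. For the measured compounds named here, only one measured step bears on the change ahead: an at least 2.4-fold higher number from compound 1 to compound 2 (0.39 log units; beyond the scatter) with butyl in place of (3-(dimethylamino)propyl)amino on a carbonyl carbon, a step beyond the scatter and of at least modest size. Compound 3 (`CCn1cc(C(CC)(CC)c2ccc(C#CC(O)(CC)CC)c(C)c2)cc1C(=O)N[C@@H](C)CO`) differs from compound 2 as follows: (1-(hydroxymethyl)ethyl)amino in place of butyl on a carbonyl carbon with (1-(hydroxymethyl)ethyl)amino in place of butyl on a carbonyl carbon. That carbonyl carbon thus carries an amino group again, as in compound 1, though a different one. Compound 1 at 20200 nM is therefore the nearest guide. A modest step toward lower numbers is expected in this assay for this change, and a further limit instead of a number would be no surprise. The estimated step is an at least 1.5-fold lower number from compound 2 to compound 3 (0.19 log units; that floor lies within the scatter) and it remains only an expectation. Compound 3 is expected at 32000 nM with an estimated range from 14000 nM to 60000 nM.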

Compound 3, half-maximal inhibitory concentration: 1910 nM
Compound 3: the middle estimate sits 17-fold (1.22 log units) above what was measured; the whole stated range lies above it.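

Placing (1-(hydroxymethyl)ethyl)amino in place of butyl on the carbonyl carbon gives, in this assay, an at least 26-fold lower number from compound 2 to compound 3 (1.41 log units; beyond the scatter), a large step that the earlier compounds gave no hint of. For the compounds shown here, the earlier pair showed only that compound 1, with its amino group on that carbon, read better than the butyl ketone; the new pair shows that the group on the amide-type nitrogen also counts, as 1-(hydroxymethyl)ethyl in place of 3-(dimethylamino)propyl gives an 11-fold lower number from compound 1 to compound 3 (1.02 log units; beyond the scatter), so the amide alone does not account for the result. The first of these steps is a floor and not an exact size, because compound 2 rests on a limit of the assay and not on a number: the limit of > 50000 nM in this assay, at which 1 of the 3 values shown sits.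

Going by these compounds, whether the gain follows the hydroxyl of the 1-(hydroxymethyl)ethyl group, its methyl branch or its defined stereocentre stays open, and a plain 2-hydroxyethyl chain or the mirror-image form of the group would be needed to separate these. On these data alone, how a longer hydroxyalkyl chain or a carboxylic acid on that amide-type nitrogen would read in this assay also remains unknown from these three compounds.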